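Acetyl removed from the 2-acetoxyethyl chain: compound 3

The compounds below may be only part of what the source reports. "The series", "measured", "known", "first", "only" and "open" are said of these compounds alone.

Measured so far:
compound 1 `Nc1ncnc2c1ccn2COCCO`: > 100000 nM
compound 2 `CC(=O)OCCOCn1cc(C#N)c2c(N)ncnc21`: > 100000 nM

In an ADME assay on BSC-1 cells (Cercopithecidae) for cytotoxicity (a higher number here means a weaker inhibitor, a lower number a stronger inhibitor), compound 1 gives only a limit, > 100000 nM. Compound 2 likewise gives only a limit, > 100000 nM. Both values sit at the limit of > 100000 nM in this assay, at which 2 of the 2 values shown sit, so compound 2 stands at the edge of what this assay reports, with no number to rank it by. Compound 3 `N#Cc1cn(COCCO)c2ncnc(N)c12` differs from compound 2 by hydrogen in place of acetyl on an oxygen on a saturated carbon. With both shown values at the limit, the step from compound 2 to compound 3 is expected to be none beyond the scatter, in neither direction. Compound 3 is therefore expected to give 150000 nM, with a range of 60000 nM to 400000 nM. The expected step is a step that the limit leaves unreadable from compound 2 to compound 3.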

Compound 3, half-maximal inhibitory concentration: > 320000 nM
Compound 3 was reported as a limit (the forecaster's own chance of this, stated with the estimate: 90%); middle value at least 2.1-fold (0.32 log units) away from the limit.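

In this assay compound 3 gives only a limit, > 320000 nM. Compound 2 also gives only a limit, > 100000 nM. Compound 1 likewise gives only a limit, > 100000 nM. Among these compounds, no step from compound 1 or compound 2 to compound 3 can be read. On these data alone, whether hydrogen in place of acetyl, or cyano in place of hydrogen, changes the read-out in this assay stays open.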